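The compounds below may be only part of what the source reports. "The series", "measured", "known", "first", "only" and "open" are said of these compounds alone.

Compound 2 `COc1ccc(CN(C(=O)CCl)c2cc(OC)c(OC)c(OC)c2)cc1O` gives 210 nM in a functional assay on KYSE-450 cells (Homo sapiens) for inhibition, read by MTT assay, with a stated time of 48 h (on this read-out lower numbers stand for stronger inhibition and higher numbers for weaker inhibition), the second highest of the three numbers recorded. Its nearest neighbour is compound 1 `CCC/C=C/C(=O)N(Cc1ccc(OC)c(O)c1)c1cc(OC)c(OC)c(OC)c1`, which gives 57 nM; the furthest is compound 3 `COc1ccc(CNc2cc(OC)c(OC)c(OC)c2)cc1C`, which gives 73800 nM. For the measured compounds named here, the only single-point step in the set, a 3.7-fold higher number from compound 1 to compound 2 (0.57 log units; beyond the scatter), shows that altering the group on the carbonyl carbon moves the number modestly. Compound 4 `COc1ccc(CN(C(C)=O)c2cc(OC)c(OC)c(OC)c2)cc1O` differs from compound 2 by hydrogen in place of chloro on a saturated chain carbon bound to a carbonyl carbon. Going by the values given here, no recorded step replaces chloro by hydrogen, so the expectation rests on the neighbouring values alone: compound 3, lacking the acyl group entirely, stands far weaker. Compound 4 is therefore expected to show a 9.5-fold higher number from compound 2 to compound 4 (0.98 log units; beyond the scatter), a weakening beyond the scatter, with an estimated value of 2000 nM (range 400 nM to 10000 nM).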

Compound 4, half-maximal inhibitory concentration: 160 nM
The estimate for compound 4 lay 13-fold (1.10 log units) above the measured number; measured number below the stated range.
By their numbers in this assay, from the lowest: compound 1; then compounds 4 and 2 (each within the scatter of the next); then compound 3.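

In this assay, hydrogen in place of chloro on a saturated chain carbon bound to a carbonyl carbon gives a 1.3-fold lower number from compound 2 to compound 4 (0.12 log units; within the scatter), so at this position the chloro makes no difference beyond the scatter. Exchanging the pent-1-en-1-yl group for methyl gives a 2.8-fold higher number from compound 1 to compound 4 (0.45 log units; beyond the scatter), which shows that compound 1 keeps a modest advantage over the acetyl as well as the (chloromethyl)carbonyl compound. Nothing given here explains these steps. The compounds shown leave open whether a longer saturated chain, an amine or a carboxylic acid on this carbonyl carbon would match pent-1-en-1-yl.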